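The compounds below may be only part of what the source reports. "The series", "measured", "known", "first", "only" and "open" are said of these compounds alone.

The compound at the start is compound 1 `CC(C)c1ccc(/C=C/C(=O)c2ccc(OCC(=O)N[C@H]3CCOC3=O)cc2)cc1`, and in a functional assay on DU-145 cells (Homo sapiens) for antiproliferative activity, read by MTT assay, with a stated time of 72 h (a lower number here means a stronger inhibitor, a higher number a weaker inhibitor), compound 1 gives 13100 nM. Two further compounds were tested on the same cells but share a different core. For compound 2 `O=C(CNc1ccc(Br)cc1)N[C@H]1CCOC1=O` this assay reports only a limit of > 64000 nM. For compound 3 `O=C(CNc1ccc(Cl)cc1)N[C@H]1CCOC1=O` this assay likewise reports only a limit of > 64000 nM. So among the three results, compound 1 holds the only actual number, while the other two rest at a limit; the step from compound 2 to compound 3, chloro in place of bromo on an aromatic carbon, is a step that the two limits leave unreadable from compound 2 to compound 3, and the fact that both sit at the limit of > 64000 nM in this assay, at which 2 of the 3 values shown sit, means it tells nothing about size.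

The new compound is compound 4 `O=C(COc1ccc(C(=O)/C=C/c2ccc(Br)cc2)cc1)N[C@H]1CCOC1=O`. Compared with compound 1 it carries bromo in place of isopropyl on an aromatic carbon, that is 4-bromophenyl where 4-isopropylphenyl stood, on an aromatic carbon para to a large group. Among the compounds with values here, none of the measured steps touches this change: the only step available compares two halogens on another core, and both of its ends are limits. Without a bearing step, the expectation is that the step from compound 1 to compound 4 stays within the usual scatter, estimated at a 1.1-fold higher number from compound 1 to compound 4 (0.06 log units; within the scatter). Compound 4 is therefore estimated at 15000 nM, expected to fall between 6000 nM and 40000 nM.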

Compound 4, half-maximal inhibitory concentration: 51700 nM
For compound 4 the middle estimate is 3.4-fold (0.54 log units) below the measured one; the measured number lies above the stated range.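

In this assay, putting bromo in place of isopropyl gives a 3.9-fold higher number from compound 1 to compound 4 (0.60 log units; beyond the scatter), so the group on this aromatic carbon, para to a large group, does affect the antiproliferative reading. The earlier compounds shown here offered only a swap between two halogens on another core, which gave no size for any change, and none at this place. The present change takes out three carbons and brings in one bromine, while the counts of hydrogen-bond donors and acceptors and the net charge stay the same, but a single step cannot say which feature of the two groups matters.

From the compounds shown here alone, with only isopropyl and bromo to compare at this place, it stays open how a chloro, an amine, a carboxylic acid or a longer chain there would read on the core of compound 1. Compound 2 and compound 3 remain limits rather than numbers, so the step between them cannot be read, and it stays open whether the two halogens differ on their own core: the limit of > 64000 nM in this assay, at which 2 of the 4 values shown sit.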